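Trading bromo for trifluoromethyl under a cytotoxicity read-out

The compounds below may be only part of what the source reports. "The series", "measured", "known", "first", "only" and "open" are said of these compounds alone.

Within the data shown here, in an ADME assay on MDBK cells (Bos taurus) for cytotoxicity, read by MTT assay, with a stated time of 72 h (a higher number here means that more compound is tolerated, a lower number that less compound is tolerated), compound 2 `FC(F)(F)c1ccc(NCc2cn(-c3ccccc3)nc2-c2ccc(Br)cc2)cc1` gives 46000 nM as the only exact number so far. Compound 1 `Cc1ccc(NCc2cn(-c3ccccc3)nc2-c2ccc(C(F)(F)F)cc2)cc1`, which also carries 4-(trifluoromethyl)phenyl, reads > 100000 nM as a limit of the assay and not a number. Compound 3 `FC(F)(F)c1ccc(NCc2cn(-c3ccccc3)nc2-c2ccc(C(F)(F)F)cc2)cc1` has trifluoromethyl in place of bromo on an aromatic carbon relative to compound 2. Among the measured compounds shown here, no measured step covers this change, and compound 1 at > 100000 nM offers only a limit as a hint. The expected step of a 1.3-fold higher number from compound 2 to compound 3 (0.12 log units; within the scatter) in this assay is small, toward more compound tolerated, perhaps none beyond the scatter. Compound 3 is estimated at 60000 nM with a range from 25000 nM to 100000 nM in this read-out.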

Compound 3, half-maximal cytotoxic concentration: 26000 nM
For compound 3 the middle estimate is 2.3-fold (0.36 log units) above the measured one, within the range that was stated.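

In this assay, 4-bromophenyl and 4-(trifluoromethyl)phenyl are not told apart at this position, with a 1.8-fold lower number from compound 2 to compound 3 (0.25 log units; within the scatter). Among these compounds, the change of methyl to trifluoromethyl on an aromatic carbon, at a different place, gives an at least 3.8-fold lower number from compound 1 to compound 3 (0.58 log units; beyond the scatter), the only step here beyond the scatter. That step rests on a limit of the assay, held by compound 1: the limit of > 100000 nM in this assay, at which 1 of the 3 values shown sits.

On these data alone, whether an amine or a carboxylic acid in place of bromo would read apart from compound 2 remains open. As far as these compounds go, the exact number for compound 1 also remains open.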